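Compound 4: bromo in place of chloro

This account rests on a few compounds, and the source may have more. Where it says the series, first, only, none or still open, it means among the compounds named here.

Measured so far:
compound 1 `CCCSc1nc(N/N=C(\C)c2ccccc2O)c2nnn(Cc3ccc(Cl)cc3)c2n1`, 11200 nM
compound 2 `C#CCSc1nc(N/N=C/c2ccc(N(C)C)cc2)c2nnn(Cc3ccccc3)c2n1`, 31300 nM
compound 3 `CCCSc1nc(N/N=C/c2c(O)ccc3ccccc23)c2nnn(Cc3ccccc3)c2n1`, 9290 nM

All three numbers come from a functional assay on ECa-109 cells (Homo sapiens) for antiproliferative activity, read by MTT assay, with a stated time of 72 h; on this read-out higher numbers stand for weaker inhibition and lower numbers for stronger inhibition. Among the three, compound 1 holds the second highest number. Its nearest neighbour is compound 3, whose number lies within the usual scatter of that of compound 1, so the two cannot be told apart. Compound 2 is the furthest away, with a number beyond the scatter and higher than that of compound 1, so compound 2 is the weaker of those two in this assay.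

Compound 4 `CCCSc1nc(N/N=C(\C)c2ccccc2O)c2nnn(Cc3ccc(Br)cc3)c2n1` has not been measured. It differs from compound 1 in one place: bromo in place of chloro on an aromatic carbon, para to a large group; read one bond further out, 4-chlorobenzyl becomes 4-bromobenzyl. Among the measured compounds shown here, no pair of measured compounds shows this change, so nothing sets its size. With a single halogen exchanged and nothing else touched, the step expected here, a 1.0-fold lower number from compound 1 to compound 4 (0.01 log units; within the scatter), is none beyond the scatter, in either direction.

For compound 4 the value expected in this assay is therefore 11000 nM, with a range from 5000 nM to 25000 nM.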

Compound 4, half-maximal inhibitory concentration: 36100 nM
Compound 4: the middle estimate sits 3.3-fold (0.52 log units) below what was measured; measured number outside the range, above it.
By their numbers in this assay, from the lowest: compounds 3 and 1 (each within the scatter of the next); then compounds 2 and 4 (each within the scatter of the next).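

In this assay, the exchange of chloro for bromo on an aromatic carbon, para to a large group, is not silent: the series now has its first step between compounds that differ in one place, a 3.2-fold higher number from compound 1 to compound 4 (0.51 log units; beyond the scatter). Chloro and bromo match in heavy-atom count and in their hydrogen-bond donor and acceptor counts, and no ring or net charge changes, yet a single halogen exchange on the 4-chlorobenzyl group is enough to move the number beyond the scatter, so this position cannot be treated as indifferent to its halogen. No measurement at hand speaks to the origin of this step.

Still open, from the compounds shown here alone, is how fluoro, methyl or methoxy would read at the same place, and so whether the numbers follow any trend across such groups or this pair stands alone. Also open, going by these compounds, is whether the chloro to bromo exchange gives a step of similar size and direction on the benzyl group of compound 2 or compound 3, where the rest of the molecule differs.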